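The source may hold more compounds than are shown below. What is called first, only, known or untested is meant among the compounds shown, and "the series" means these compounds.

Measured compounds:
- compound 1, `CC(=O)c1ccc(NC(=O)C(C(C)C)N(C(=O)c2ccccc2)S(=O)(=O)c2ccc(C)cc2)cc1`, in a functional assay for inhibition, read by spectrophotometry, with a stated time of 20 min, tested at 4 mg/mL (a lower number here means a weaker effect, a higher number a stronger effect of the compound at the concentration tested), compound 1 gives 36.6%
- compound 2, `CC(=O)c1ccc(NC(=O)C(CC(C)C)N(C(=O)c2ccccc2)S(=O)(=O)c2ccc([N+](=O)[O-])cc2)cc1`, compound 2 gives 71%
- compound 3, `CCC(C)C(C(=O)Nc1ccc(C(C)=O)cc1)N(C(=O)c1ccccc1)S(=O)(=O)c1ccc([N+](=O)[O-])cc1`, compound 3 gives 48.4%

On these three numbers compound 3 stands second highest: compound 2 sits above it, beyond the scatter, and compound 1 sits below it, also beyond the scatter. Within the data shown here, the one step that changes a single place is a number 22.6 percentage points lower from compound 2 to compound 3 (beyond the scatter), where the saturated chain carbon bound to the amide-type nitrogen and the carbonyl carbon carries a different branched chain.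

Compound 4, `CC(=O)c1ccc(NC(=O)C(C(C)C)N(C(=O)c2ccccc2)S(=O)(=O)c2ccc([N+](=O)[O-])cc2)cc1`, is not yet measured. It differs from compound 3 as follows: hydrogen in place of methyl on a saturated chain carbon, three bonds along the chain from an amide-type nitrogen and a carbonyl carbon. Among the measured compounds shown here, no measured step covers this exact change. The step from compound 2 to compound 3 shows that altering the branched chain at this position can move the read-out by a modest amount, and compound 1, which also carries isopropyl there but with methyl instead of nitro on the sulfonyl aryl, gives the lowest number of the three. Compound 4 is therefore expected to fall somewhat below compound 3, with the step of a number 6.4 percentage points lower from compound 3 to compound 4 (within the scatter) estimated as modest, and a value of 42% (range 25% to 60%) is expected.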

Compound 4, a percentage reported as inhibition, at one concentration (the size of the read-out at that concentration, not a potency): 27.2%
Estimate against measurement, compound 4: 14.8 percentage points above; measured number inside the range.
By their numbers in this assay, from the lowest: compounds 4 and 1 (each within the scatter of the next); then compound 3; then compound 2.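

In this assay, hydrogen in place of methyl on the sec-butyl chain, leaving isopropyl, gives a number 21.2 percentage points lower from compound 3 to compound 4 (beyond the scatter), so a single carbon at this place moves the read-out beyond the scatter. Isopropyl in place of isobutyl gives a number 43.8 percentage points lower from compound 2 to compound 4 (beyond the scatter), which makes this the largest step in the series so far and places the three nitro compounds in the order compound 2, compound 3, compound 4, from the highest number down. With isopropyl held, nitro in place of methyl on the aromatic carbon gives a number 9.4 percentage points lower from compound 1 to compound 4 (within the scatter), which lies within the scatter, so that exchange has no readable effect on this chain.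

From the compounds shown here alone, whether a longer chain or a benzyl group on this carbon would exceed isobutyl remains open, as does the nitro-for-methyl exchange with isobutyl held. Nothing available explains these steps.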